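A few compounds are considered here, and "the series" means these few. Any claim that something is new, unique, unknown or untested is made for them only; others in the source may bear on it.

Compound 2 `Cc1nn(C)cc1Nc1nc(N)c2c(C#N)c(N3CCC[C@H]3C)n(C)c2n1` is one of three closely related compounds measured in an assay on isolated protein for inhibition of Leucine-rich repeat serine/threonine-protein kinase 2 (Homo sapiens), read by TR-FRET and LanthaScreen, with stated times of 50 min and 30 min, in the presence of a further agent that is not named here; a higher number here means a weaker inhibitor, a lower number a stronger inhibitor. In this assay compound 2 gives 38 nM. Compound 1 `Cc1nn(CC2(O)COC2)cc1Nc1nc(N)c2c(C#N)c(N3CCC[C@H]3C)n(C)c2n1` gives 57 nM, and compound 3 `Cc1nn(CC(C)(C)O)cc1Nc1nc(N)c2c(C#N)c(N3CCC[C@H]3C)n(C)c2n1` gives 49 nM. The step of a 1.5-fold lower number from compound 1 to compound 2 (0.18 log units; within the scatter) and the step of a 1.3-fold higher number from compound 2 to compound 3 (0.11 log units; within the scatter) both lie within the scatter, as does a 1.2-fold lower number from compound 1 to compound 3 (0.07 log units; within the scatter); the three values therefore sit together, and compound 2 cannot be told apart from the other two on these numbers.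

Compound 4 `C[C@@H]1CCCN1c1c(C#N)c2c(N)ncnc2n1C` is not yet measured in this assay. Relative to compound 2 it carries hydrogen in place of (1,3-dimethyl-1H-pyrazol-4-yl)amino on an aromatic carbon. For the measured compounds named here, none of the measured steps bears directly on this change: each of them alters only the substituent on the saturated chain carbon bound to the aromatic nitrogen of the pyrazole, while the pyrazole and its attached amino group remain in place throughout compounds 1, 2 and 3. The data thus say nothing about what happens when the whole (1,3-dimethyl-1H-pyrazol-4-yl)amino group is removed. Given that a larger part of the molecule is lost than in any measured step, compound 4 is expected to give a much higher number, estimated at 5000 nM with a range from 500 nM to 30000 nM, a step of a 130-fold higher number from compound 2 to compound 4 (2.12 log units; beyond the scatter), and it is possible that this assay will report only a limit.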

Compound 4, half-maximal inhibitory concentration: 15 nM
The estimate for compound 4 lay 330-fold (2.52 log units) above the measured number; the measured number lies below the stated range.
By their numbers in this assay, from the lowest: compound 4; then compounds 2, 3 and 1 (each within the scatter of the next).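

In this assay the (1,3-dimethyl-1H-pyrazol-4-yl)amino group proves dispensable at this aromatic carbon: replacing it with hydrogen gives a 2.5-fold lower number from compound 2 to compound 4 (0.40 log units; beyond the scatter) and so removes 8 heavy atoms, including a five-membered aromatic ring, with a modest gain in inhibition rather than a loss. Compounds 1, 2 and 3 changed only the substituent on the saturated chain carbon of the pyrazole and kept the group itself, so their steps, all within the scatter, could not show that the shared core gives a low number without it; compound 4 shows this, and its step is the only one here beyond the scatter. No measurement given here explains why the smaller compound gives the lower number.

As far as these compounds go, it remains open whether something between these two extremes, such as a plain amino group, a methylamino group or a methyl group on the same carbon, would give a number nearer to that of compound 4 or compound 2. Nor does this single pair show whether removing the group would have a similar effect if the nitrile were replaced by a chlorine atom or a carboxamide.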